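Replacing the 2-fluorophenyl group of compound 3

The source may hold more compounds than are shown below. What is called first, only, known or untested is meant among the compounds shown, and "the series" means these compounds.

Of the compounds shown here, three have so far been tested in a functional assay on U-937 cells (Homo sapiens) for antiproliferative activity, read by MTT assay, with a stated time of 24 h; a lower number here means a stronger inhibitor of growth, a higher number a weaker inhibitor of growth. Compound 1 (`Cc1ccc(NC(=O)c2ccccc2Sc2ccccc2C#N)cc1NC(=O)c1cnoc1C`) gives > 30000 nM, which is a limit of the assay and not a number. Compound 2 (`Cc1ccc(NC(=O)Nc2cccc(Cl)c2)cc1NC(=O)c1cnoc1C`) gives > 30000 nM, again a limit. Compound 3 (`Cc1cc(NC(=O)Nc2ccccc2F)ccc1NC(=O)c1cnoc1C`) gives > 30000 nM, also a limit, so it has no number from which to measure a change.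

Compound 4 (`Cc1cc(NC(=O)Nc2cc(Cl)cc(Cl)c2)ccc1NC(=O)c1cnoc1C`) has 3,5-dichlorophenyl in place of 2-fluorophenyl on an amide-type nitrogen, and the counted difference is 3,5-dichlorophenyl in place of 2-fluorophenyl on an amide-type nitrogen. Among the measured compounds shown here, no two tested compounds differ in one place only, so no measured step can serve as a guide. The expectation therefore rests on (the limit of > 30000 nM in this assay, at which 3 of the 3 values shown sit). Little gain in growth inhibition is expected in this assay, and another limit is the likeliest result, though a modest measurable gain remains possible. The expected change is an at least 1.5-fold lower number from compound 3 to compound 4 (0.17 log units; that floor lies within the scatter). For compound 4 the estimate is 20000 nM, with an expected range from 6000 nM to 40000 nM.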

Compound 4, concentration for 50% growth inhibition: > 30000 nM
Compound 4: a limit, no number; the forecaster's own chance of this, stated with the estimate: 60%; middle value at least 1.5-fold (0.17 log units) away from the limit.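

Compound 3 and compound 4 both end at a limit of the assay and not at a number, so the step between them cannot be read. The compounds shown leave open which change, if any, would give a measurable value in this assay, as all of them share one result: the limit of > 30000 nM in this assay, at which 4 of the 4 values shown sit.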